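The compounds below may be only part of what the source reports. "The series", "measured", "known", "first", "only" and "open" are said of these compounds alone.

Measured in a functional assay on HCT-116 cells (Homo sapiens) for antiproliferative activity, read by MTT assay, with a stated time of 48 h; on this read-out lower numbers stand for stronger inhibition and higher numbers for weaker inhibition:
- compound 1 `COc1ccc(/C=C/C(=O)c2cc(OC)c(OC)c(OC)c2)cc1OCCCC(=O)NCCCNCCCCNCCN`: 55800 nM
- compound 2 `COc1cc(C(=O)/C=C/c2ccc(OCCCC(=O)NCCCNCCCCN)cc2)cc(OC)c1OC`: > 100000 nM
- compound 3 `COc1ccc(/C=C/C(=O)c2cc(OC)c(OC)c(OC)c2)cc1OCCCC(=O)NCCCCN(CCCN)CCCCNCCCN`: 29500 nM

All three compounds sit at the weak end of the scale. Compound 3 gives 29500 nM and compound 1 gives 55800 nM, so these two lie within the usual scatter of each other. For compound 2 the entry is a limit of the assay and not a number: > 100000 nM.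

Compound 4 `COc1ccc(/C=C/C(=O)c2cc(OC)c(OC)c(OC)c2)cc1OCCCC(=O)NCCCCNCCCN` has hydrogen in place of 4-((3-aminopropyl)amino)butyl on an amine nitrogen of compound 3 (hydrogen in place of 4-((3-aminopropyl)amino)butyl on an amine nitrogen). Within the data shown here, no measured pair shows this change on its own, so any expectation in this assay is loose. Compound 1, at 55800 nM, stays within the scatter of compound 3 despite its different chain, which argues against a large jump. The estimated step of a 1.5-fold higher number from compound 3 to compound 4 (0.18 log units; within the scatter) is therefore small, leaning towards weaker inhibition and probably not beyond the scatter. For compound 4 the estimated value is 45000 nM, with an expected range of 15000 nM to 100000 nM.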

Compound 4, half-maximal inhibitory concentration: 38000 nM
Compound 4: middle estimate off by 1.2-fold (0.07 log units), on the high side; the range from low to high includes it.
By their numbers in this assay, from the lowest: compounds 3, 4 and 1 (each within the scatter of the next). At a limit, above all of these: compound 2.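

Replacing the 4-((3-aminopropyl)amino)butyl group on this amine nitrogen with hydrogen gives a 1.3-fold higher number from compound 3 to compound 4 (0.11 log units; within the scatter) in this assay, so removing this whole branch produces no change that can be told from scatter. Changing the chain further along, with ((3-aminopropyl)amino)methyl in place of (4-((2-aminoethyl)amino)butyl)amino on a saturated chain carbon, three bonds along the chain from an amide-type nitrogen, gives a 1.5-fold lower number from compound 1 to compound 4 (0.17 log units; within the scatter), which is also no clear change. The measurements offer no explanation for why these chains perform alike.

Going by these compounds, it remains open whether a carboxylic acid or a guanidine at the end of the chain would move the value beyond the scatter. On these data alone, it is also open how the shared core would fare with a simple methoxy group in place of the whole chain.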